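Replacing the Side Chain of Compound 1 with Carboxy

The compounds below may be only part of what the source reports. "The series", "measured", "known", "first", "only" and "open" are said of these compounds alone.

Three compounds have so far been measured in a functional assay on the whole organism (Tail, strain ICR) with Mus musculus as the target, in the tail flick test, with a stated time of 90 min, at a dose of 25 umol/kg by the oral route; a lower number here means a weaker effect, a higher number a stronger effect of the compound at the dose given:
compound 1 `N=C(N)NCCC[C@H](NC(=O)CN(c1nc(Cl)nc2[nH]cnc12)C1CC1)C(=O)O` gives 27.6%;
compound 2 `O=C(OCc1ccccc1)[C@@H]1CCCN1C(=O)CN(c1nc(Cl)nc2[nH]cnc12)C1CC1` gives 43.3%;
compound 3 `N=C(N)NCCC[C@H](NC(=O)CN(c1nc(Cl)nc2[nH]cnc12)C1CC1)C(=O)OCc1ccccc1` gives 30.4%.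

Compound 1 has the lowest of the three numbers. Its nearest neighbour is compound 3, with a number higher by a number 2.8 percentage points higher from compound 1 to compound 3 (within the scatter), a step within the scatter that comes from a benzyl in place of hydrogen on an oxygen next to a carbonyl group. Compound 2 lies furthest away, beyond the scatter, but it differs from compound 1 in more than one place, so no single step can be read from that pair.

Compound 4 `O=C(O)C[C@H](NC(=O)CN(c1nc(Cl)nc2[nH]cnc12)C1CC1)C(=O)O` differs from compound 1 as follows: a group of 3 heavy atoms (1 carbon, 2 oxygen; no ring) in place of a group of 6 heavy atoms (3 carbon, 3 nitrogen; no ring), on a saturated chain carbon, two bonds along the chain from an amide-type nitrogen and a carbonyl carbon. Among the measured compounds shown here, no measured step touches this part of the molecule; the only known step, a number 2.8 percentage points higher from compound 1 to compound 3 (within the scatter), concerns the ester end and is within the scatter. From the compounds shown here alone, the expectation therefore rests on compound 1 alone, and the expected step is a number 0.4 percentage points higher from compound 1 to compound 4 (within the scatter), none beyond the scatter, with a wide range for what is unknown. Compound 4 is estimated at 28%, between 14% and 42%.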

Compound 4, a percentage reported as activity, at one dose (the size of the read-out at that dose, not a potency): 25.1%
The estimate for compound 4 lay 2.9 percentage points above the measured number; the measured number falls inside the stated range.
By their numbers in this assay, from the lowest: compounds 4, 1 and 3 (each within the scatter of the next); then compound 2.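

The earlier step concerned only the ester end, whereas this one reaches the side chain: carboxy in place of the group of 6 heavy atoms (3 carbon, 3 nitrogen; no ring), on a saturated chain carbon, gives a number 2.5 percentage points lower from compound 1 to compound 4 (within the scatter) in this assay. At this one dose, then, the read-out does not separate these two quite different groups, so the group of 6 heavy atoms is not required for the effect that compound 1 shows. No measurement available here offers an explanation for this result.

The compounds shown leave open whether a side chain ending in an amine, or a longer chain ending in a carboxylic acid, would give a different number from compound 1. From the compounds shown here alone, it also remains open what carboxy at this position gives when combined with the benzyl ester that compound 3 carries.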